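The source may report more compounds than this note shows. Statements on the series, on what has been measured and on what is new or still open speak of the compounds shown alone.

Measured so far:
Compound 1 `Cc1nc(N2CCN(C)CC2)c2nc(-c3cccc(Cl)c3)n(C3CCOCC3)c2n1`: 45%
Compound 2 `Cc1nc(N2CCN(C)CC2)c2nc(-c3cccc(C(F)(F)F)c3)n(C3CCOCC3)c2n1`: 44%
Compound 3 `COc1ccccc1-c1nc2c(N3CCN(C)CC3)nc(C)nc2n1C1CCOCC1`: 36%

All three were tested in an ADME assay (liver) for metabolic stability, with Liver microsome (Canis lupus familiaris) as the target, read by LC-MS, using microsomes, with a stated time of 30 min, tested at 4 uM (a lower number here means that less of the compound is left, a higher number that more of the compound is left), and compound 3 stands within the scatter of both others: a number 9 percentage points lower from compound 1 to compound 3 (within the scatter) and a number 8 percentage points lower from compound 2 to compound 3 (within the scatter). Compound 4 `Cc1nc(N2CCN(C)CC2)c2nc(-c3ccccc3C#N)n(C3CCOCC3)c2n1` carries cyano in place of methoxy on an aromatic carbon. Within the data shown here, no measured step makes this exact swap. The nearest evidence is those two steps, which change the aromatic substituent, together with a number 1 percentage points lower from compound 1 to compound 2 (within the scatter). None of them exceeds the scatter, so no step beyond the scatter is expected in this assay, and no direction can be favoured. The estimated step is a number 4 percentage points higher from compound 3 to compound 4 (within the scatter). For compound 4 the expected value is 40%, with an estimated range of 27% to 54%.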

Compound 4, percent of the compound remaining: 11%
Beside the measured number, compound 4's estimate is 29 percentage points above it; measured number outside the range, below it.
By their numbers in this assay, from the lowest: compound 4; then compounds 3, 2 and 1 (each within the scatter of the next).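

In this assay, among these compounds, the aromatic substituent had looked unimportant, yet cyano in place of methoxy, on the same aromatic carbon ortho to a large group, gives a number 25 percentage points lower from compound 3 to compound 4 (beyond the scatter) and is the first change to pass the scatter. The 2-cyanophenyl group also gives a number 33 percentage points lower from compound 2 to compound 4 (beyond the scatter) in place of 3-(trifluoromethyl)phenyl and a number 34 percentage points lower from compound 1 to compound 4 (beyond the scatter) in place of 3-chlorophenyl. So this position can matter for how much compound is left.

From the compounds shown here alone, how a carboxylic acid or an amide on this aromatic carbon would read stays open. Nothing available explains why cyano gives this result.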